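The source may report more compounds than this note shows. Statements on the series, on what has been measured and on what is new or still open speak of the compounds shown alone.

Compound 1 `O=C(Nc1cccc(-c2oc3cc(-c4ccc(F)cc4)ccc3c(=O)c2O)c1)c1ccc(F)cc1` carries a fluoro group on the benzamide ring of the shared core. In a functional assay on HCC1937 cells (Homo sapiens) for antiproliferative activity, read by CCK-8 assay, with a stated time of 72 h (a lower number here means a stronger inhibitor, a higher number a weaker inhibitor), compound 1 gives 14200 nM, the highest of the three numbers shown. Compound 2 `Cc1cc(C(=O)Nc2cccc(-c3oc4cc(-c5ccc(F)cc5)ccc4c(=O)c3O)c2)ccc1F` gives 5420 nM, and compound 3 `O=C(Nc1cccc(-c2oc3cc(-c4ccc(F)cc4)ccc3c(=O)c2O)c1)c1ccc(Cl)nc1` gives 7550 nM. The changes at this amide end were a 2.6-fold lower number from compound 1 to compound 2 (0.42 log units; beyond the scatter) and a 1.9-fold lower number from compound 1 to compound 3 (0.27 log units; within the scatter). Compound 4 `N#Cc1ccc(C(=O)Nc2cccc(-c3oc4cc(-c5ccc(F)cc5)ccc4c(=O)c3O)c2)cc1` differs from compound 1 by cyano in place of fluoro on an aromatic carbon. For the measured compounds named here, no measured step tests a cyano group, but both changes at this end moved the number only modestly, so for compound 4 a small step downward or none beyond the scatter is expected: a 1.4-fold lower number from compound 1 to compound 4 (0.15 log units; within the scatter). Compound 4 is estimated at 10000 nM, within 4000 nM to 25000 nM.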

Compound 4, half-maximal inhibitory concentration: 2990 nM
Compound 4: middle estimate off by 3.3-fold (0.52 log units), on the high side, and the stated range ends above it.
By their numbers in this assay, from the lowest: compounds 4, 2, 3 and 1 (each within the scatter of the next, the first and the last beyond it).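

In this assay, replacing the fluoro group alone at this position, para to a large group, moves the number beyond the scatter (a 4.7-fold lower number from compound 1 to compound 4 (0.68 log units; beyond the scatter)). The 4-cyanophenyl amide also separates from the 6-chloropyridin-3-yl amide (a 2.5-fold lower number from compound 3 to compound 4 (0.40 log units; beyond the scatter)), but not from the 4-fluoro-3-methylphenyl amide (a 1.8-fold lower number from compound 2 to compound 4 (0.26 log units; within the scatter)). Nothing measured here gives a reason for these steps.

The compounds shown leave open whether an amine, a carboxylic acid or a longer chain at this position would lower the number further. They also leave open whether adding methyl to the 4-cyanophenyl ring would change it.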